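The source may report more compounds than this note shows. Statements on the series, on what has been measured and on what is new or still open speak of the compounds shown alone.

Of the compounds shown here, three have been measured in a functional assay on U-251 cells (Homo sapiens) (a higher number here means a weaker inhibitor of growth, a lower number a stronger inhibitor of growth), and a fourth awaits its number. Compound 1 `COc1ccc(-c2cc(O)c3cccnc3n2)cc1` gives 53700 nM. Among the measured compounds shown here, compound 2 `COc1cccc(-c2cc(O)c3c(C)ccnc3n2)c1` gives 58.9 nM, the lowest of the two numbers so far. Compound 3 `COc1ccc(-c2cc(O)c3ccc(C)nc3n2)cc1` gives > 100000 nM, which is a limit of the assay rather than a number. That value sits at a limit: the limit of > 100000 nM in this assay, at which 1 of the 3 values shown sits. Compound 2 and compound 3 are built from the same atoms joined differently, and the difference between their two cores is not broken down here.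

From compound 3 to compound 1 one change is made: hydrogen in place of methyl on an aromatic carbon. It gives an at least 1.8-fold lower number from compound 3 to compound 1 (0.27 log units; that floor lies within the scatter). The same kind of change leads from compound 2 to compound 4 `COc1cccc(-c2cc(O)c3cccnc3n2)c1`: hydrogen in place of methyl on an aromatic carbon. The place is not the same: in compound 3 the methyl sits next to the ring nitrogen and para to a fused ring, in compound 2 it sits ortho to a fused ring and opposite the ring nitrogen.

From compound 2 to compound 4 the step is expected to be a 5.1-fold higher number from compound 2 to compound 4 (0.71 log units; beyond the scatter), a guess resting on the first step because the earlier removal gave an at least 1.8-fold lower number from compound 3 to compound 1 (0.27 log units; that floor lies within the scatter). Compound 4 is expected at 300 nM, with a range from 50 nM to 5000 nM.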

Compound 4, concentration for 50% growth inhibition: 55 nM
For compound 4 the middle estimate is 5.5-fold (0.74 log units) above the measured one, and the stated range covers the measured number.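

On the core of compound 2, in this assay, putting hydrogen in place of methyl gives a step that lies within the usual scatter: a 1.1-fold lower number from compound 2 to compound 4 (0.03 log units; within the scatter). This shows that, on this core, the methyl can be given up without a step beyond the scatter, but it does not show that the change carries over in the same way to another core, and the methyl of compound 3 also sits at a different place from that of compound 2. Set beside each other, the two steps cannot be told apart: the same change on two cores in this assay, an at least 1.8-fold lower number (0.27 log units; that floor lies within the scatter) from compound 3 to compound 1 and a 1.1-fold lower number (0.03 log units; within the scatter) from compound 2 to compound 4; the limit leaves it open whether they differ

The compounds shown carry only hydrogen or methyl at these places, so it stays open what an ethyl group, a longer chain, an amine or a carboxylic acid would give there. On these data alone, it also stays open whether any such group would give the same result on the core of compound 1 as on the core of compound 4.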